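Benzyl for Phenyl on the Amide Nitrogen

This account rests on a few compounds, and the source may have more. Where it says the series, first, only, none or still open, it means among the compounds named here.

Compound 1 `O=C(O)c1ccc(N(C(=O)CCCCCBr)c2ccc(C(=O)O)cc2)cc1` is the simplest member here; in an assay on isolated protein for binding affinity to E-selectin (Homo sapiens), read by ELISA, tested at 100 uM (on this read-out higher numbers stand for more inhibition at the one concentration tested (going by the name of the read-out) and lower numbers for less inhibition), compound 1 gives 5%. Compound 2 `CCCCCCCCCCOc1cc(OCCCCCCCCCC)cc(OCCCCCC(=O)N(c2cccc(C(=O)O)c2)c2cccc(C(=O)O)c2)c1` is the extended analogue, yet in this assay compound 2 gives "not determined" (no result reported), so compound 2 stands nowhere on the numbers. Compound 3 `CCCCCCCCCCOc1cc(OCCCCCCCCCC)cc(OCCCCCC(=O)N(Cc2ccc(C(=O)O)cc2)c2cccc(C(=O)O)c2)c1` differs from compound 2 in one place: 4-carboxybenzyl in place of 3-carboxyphenyl on an amide-type nitrogen. For the measured compounds named here, no measured pair covers this change, and compound 1 shows only weak inhibition; a step no larger than the usual scatter is expected, with no clear direction. Compound 3 is expected to give about 12%, ranging from 0% to 35%.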

Compound 3, a percentage reported as inhibition, at one concentration (the size of the read-out at that concentration, not a potency): 43%
Beside the measured number, compound 3's estimate is 31 percentage points below it; measured number above the stated range.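

For the compounds shown here, compound 2 carries no number in this assay so no step to compound 3 can be read. On these data alone, whether 4-carboxybenzyl in place of 3-carboxyphenyl on the amide-type nitrogen changes inhibition stays open. No evidence here bears on the result.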